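Notes on the series: the carbamoyl to benzoyl step

The compounds below may be only part of what the source reports. "The series", "measured", "known", "first", "only" and "open" are said of these compounds alone.

Of the compounds shown here, two have been measured in a functional assay on HOP-92 cells (Homo sapiens) for inhibition, read by sulforhodamine B assay, with a stated time of 48 h; on this read-out lower numbers stand for stronger inhibition of growth and higher numbers for weaker inhibition of growth. Compound 1 `N#C/C(=C\N1CCN(C(=O)c2ccco2)C1=S)C(=O)Nc1ccc(Cl)cc1` gives 21500 nM in this assay, and compound 2 `N#C/C(=C\N1CCN(C(=O)c2ccco2)C1=S)C(N)=O` gives 25500 nM; the two values lie within the scatter of each other, so neither can be placed ahead of the other. For the measured compounds named here, the one measured step, a 1.2-fold higher number from compound 1 to compound 2 (0.07 log units; within the scatter), replaces a 4-chlorophenyl on an amide-type nitrogen with hydrogen and leaves the number essentially where it was.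

Compound 3 `N#C/C(=C\N1CCN(C(=O)c2ccco2)C1=S)C(=O)c1ccccc1` is not yet measured. It differs from compound 2 by phenyl in place of amino on a carbonyl carbon, that is, carbamoyl to benzoyl. Going by the values given here, no measured step touches this position; the only step in hand, from compound 1 to compound 2, changed what hangs on the amide nitrogen and stayed within the scatter, which gives little reason to expect a large move from a change on the carbonyl carbon itself. The step of a 1.2-fold lower number from compound 2 to compound 3 (0.06 log units; within the scatter) is therefore expected to stay within the scatter, with no clear direction. Compound 3 is estimated at 22000 nM in this assay, in a range from 7000 nM to 70000 nM.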

Compound 3, concentration for 50% growth inhibition: 26900 nM
Beside the measured number, compound 3's estimate is 1.2-fold (0.09 log units) below it, and the stated range covers the measured number.
By their numbers in this assay, from the lowest: compounds 1, 2 and 3 (each within the scatter of the next).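

In this assay, the carbonyl carbon now has a measured change of its own: a 1.1-fold higher number from compound 2 to compound 3 (0.02 log units; within the scatter), with phenyl in place of amino, and this step stays within the scatter although it brings in a six-membered aromatic ring and removes a hydrogen-bond donor. The second new step, a 1.3-fold higher number from compound 1 to compound 3 (0.10 log units; within the scatter), with phenyl in place of (4-chlorophenyl)amino, also stays within the scatter, so amino, (4-chlorophenyl)amino and phenyl on this carbonyl carbon cannot be told apart by this read-out, and the nitrogen attached to the carbonyl in compound 1 and compound 2 is not required to hold the number in this range. Nothing in hand bears on why these changes leave the number in place.

On these data alone, it remains open whether a carboxylic acid, a methyl ester or a longer alkyl chain at this carbonyl carbon would move the number beyond the scatter. The compounds shown also leave open whether any change to the shared core, rather than to this carbonyl substituent, would do so.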